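Compound 1 to compound 3: replacing trifluoromethyl

The source may report more compounds than this note shows. Statements on the series, on what has been measured and on what is new or still open speak of the compounds shown alone.

Measured compounds:
- Compound 1 `CNC(=O)[C@@H]1CCCN1S(=O)(=O)c1ccc(Cl)c(COc2cccc3c(C(F)(F)F)cc(C)nc23)c1Cl`: 250 mL/min/kg
- Compound 2 `Cc1cc(C(F)(F)F)c2cccc(OCc3c(Cl)ccc(S(=O)(=O)N4CCCC4)c3Cl)c2n1`: 233 mL/min/kg

In an ADME assay on microsomes (Homo sapiens) for metabolic stability (on this read-out lower numbers stand for slow clearance and higher numbers for fast clearance), compound 1 gives 250 mL/min/kg and compound 2 gives 233 mL/min/kg, so the two lie within the scatter of each other and cannot be ranked. The next compound is compound 3 `CNC(=O)[C@@H]1CCCN1S(=O)(=O)c1ccc(Cl)c(COc2cccc3c(-c4ccncc4)cc(C)nc23)c1Cl`, with pyridin-4-yl in place of trifluoromethyl on an aromatic carbon. Among the compounds with values here, the only measured step, a 1.1-fold lower number from compound 1 to compound 2 (0.03 log units; within the scatter), replaces methylcarbamoyl on a saturated ring carbon, elsewhere in the structure. Within the data shown here, it bears only indirectly on this change, and no measured pair tests the trifluoromethyl group. Among the measured compounds shown here, with no direct precedent, a moderate shift towards lower numbers in this assay is expected, although no change beyond the scatter remains plausible. The expected step is a 1.5-fold lower number from compound 1 to compound 3 (0.17 log units; within the scatter). For compound 3 the estimated value is 170 mL/min/kg, with an expected range of 70 mL/min/kg to 300 mL/min/kg.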

Compound 3, clearance: 217 mL/min/kg
Compound 3: the middle estimate sits 1.3-fold (0.11 log units) below what was measured, and the stated range covers the measured number.
By their numbers in this assay, from the lowest: compounds 3, 2 and 1 (each within the scatter of the next).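

In this assay, pyridin-4-yl in place of trifluoromethyl on the aromatic carbon opposite the ring nitrogen gives a 1.2-fold lower number from compound 1 to compound 3 (0.06 log units; within the scatter), so this exchange produces no separable shift in clearance. The entering group brings an aromatic ring and a hydrogen-bond acceptor that trifluoromethyl lacks, yet the read-out of compound 3 cannot be told apart from that of compound 1. No supporting measurement bears on why the number stays where it does.

On these data alone, whether any group on this aromatic carbon can move the number beyond the scatter remains open, and a nitrile, a carboxylic acid or a dimethylamino group there would test it. Also open, as far as these compounds go, is whether pyridin-4-yl behaves the same way on the core of compound 2, which has hydrogen in place of methylcarbamoyl.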